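The compounds below may be only part of what the source reports. "The series", "measured", "known", "first", "only" and "open" are said of these compounds alone.

- compound 1 `COc1ccc(S(=O)(=O)N2CCc3cccc(Nc4ccccc4)c32)cc1`: 342 nM
- compound 2 `COc1ccc(Nc2cccc3c2N(S(=O)(=O)c2ccc(OC)cc2)CC3)cc1`: 1200 nM
- compound 3 `COc1ccc(S(=O)(=O)N2CCc3cccc(Nc4ccc([N+](=O)[O-])cc4)c32)cc1`: 101 nM

In a functional assay on KB cells (Homo sapiens) for antiproliferative activity (on this read-out lower numbers stand for stronger inhibition and higher numbers for weaker inhibition), compound 3 gives the lowest of the three numbers, 101 nM, and its steps to both others lie beyond the scatter. The next change leads to compound 4 `COc1ccc(S(=O)(=O)N2CCc3cccc(Nc4ccc(C#N)cc4)c32)cc1`, with cyano in place of nitro on an aromatic carbon, para to a large group: cyano in place of nitro on an aromatic carbon. Among the measured compounds shown here, no measured step involves cyano, so the evidence is indirect. Nitro in place of hydrogen gave a modest step, a 3.4-fold lower number from compound 1 to compound 3 (0.53 log units; beyond the scatter), and nitro in place of methoxy gave a large one, a 12-fold lower number from compound 2 to compound 3 (1.07 log units; beyond the scatter). Methoxy in place of hydrogen went the other way, a 3.5-fold higher number from compound 1 to compound 2 (0.55 log units; beyond the scatter). Only a small rise, not beyond the scatter, is therefore expected, and the expected step is a 1.5-fold higher number from compound 3 to compound 4 (0.17 log units; within the scatter). The estimate for compound 4 is 150 nM, with an expected range of 50 nM to 450 nM.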

Compound 4, half-maximal inhibitory concentration: 49.7 nM
For compound 4 the middle estimate is 3.0-fold (0.48 log units) above the measured one, outside the stated range (below it).
By their numbers in this assay, from the lowest: compound 4; then compound 3; then compound 1; then compound 2.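

In this assay cyano in place of nitro gives a 2.0-fold lower number from compound 3 to compound 4 (0.31 log units; beyond the scatter) and so the two groups do not read as equivalent at this place, para to a large group. Cyano also stands well apart from the other two groups, with a 6.9-fold lower number from compound 1 to compound 4 (0.84 log units; beyond the scatter) for cyano in place of hydrogen and a 24-fold lower number from compound 2 to compound 4 (1.38 log units; beyond the scatter) for cyano in place of methoxy. Across these four compounds cyano and nitro both give lower numbers than hydrogen while methoxy gives a higher one, and nothing available explains this order. On these data alone, whether a carboxylic acid, an amine or a chlorine atom at this place would fall in with cyano and nitro stays open. So does whether the same order holds at other places on this ring.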